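The compounds below may be only part of what the source reports. "The series", "measured", "known", "first", "only" and "open" are said of these compounds alone.

Within the data shown here, compound 3 `CC1(C)S[C@@H]2/C(=C\C(=O)c3ccc(C(F)(F)F)cc3)C(=O)N2[C@H]1C(=O)OC(c1ccccc1)c1ccccc1` gives 15600 nM in a functional assay on OE19 cells (Homo sapiens) for cytotoxicity, read by MTT assay, with a stated time of 48 h (a higher number here means a weaker inhibitor, a lower number a stronger inhibitor), the lowest of the three numbers so far, though only its gap to compound 2 lies beyond the scatter. Compound 1 `CC1(C)S[C@@H]2/C(=C\C(=O)c3ccc4ccccc4c3)C(=O)N2[C@H]1C(=O)OC(c1ccccc1)c1ccccc1` gives 19500 nM and compound 2 `CC1(C)S[C@@H]2/C(=C\C(=O)c3ccco3)C(=O)N2[C@H]1C(=O)OC(c1ccccc1)c1ccccc1` gives 54300 nM in this assay. Both measured steps into compound 3 swap the whole aryl group on the carbonyl: a 1.3-fold lower number from compound 1 to compound 3 (0.10 log units; within the scatter), while a 3.5-fold lower number from compound 2 to compound 3 (0.54 log units; beyond the scatter). Compound 4 `CC1(C)S[C@@H]2/C(=C\C(=O)c3ccc([N+](=O)[O-])cc3)C(=O)N2[C@H]1C(=O)OC(c1ccccc1)c1ccccc1` keeps the six-membered carbon ring and differs from compound 3 in one place: nitro in place of trifluoromethyl on an aromatic carbon. Among the measured compounds shown here, no measured step exchanges one substituent on that ring for another, so the data offer no direct guide. What they do show is that a singly substituted six-membered carbon ring and a naphthalen-2-yl ring gave numbers within the scatter of each other, and only the furan-2-yl ring of compound 2 stood apart. The step is therefore expected to be a 1.1-fold higher number from compound 3 to compound 4 (0.04 log units; within the scatter), inside the scatter. Compound 4 is estimated at 17000 nM, with a range from 8000 nM to 40000 nM.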

Compound 4, half-maximal inhibitory concentration: 44100 nM
The estimate for compound 4 lay 2.6-fold (0.41 log units) below the measured number; measured number outside the range, above it.
By their numbers in this assay, from the lowest: compounds 3 and 1 (each within the scatter of the next); then compounds 4 and 2 (each within the scatter of the next).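

At this position, para to a large group, the exchange of one substituent for another is not neutral in this assay: there is a 2.8-fold higher number from compound 3 to compound 4 (0.45 log units; beyond the scatter) for nitro in place of trifluoromethyl, so a singly substituted six-membered carbon ring does not by itself settle the number. The 4-nitrophenyl group also parts from the naphthalen-2-yl group, with a 2.3-fold higher number from compound 1 to compound 4 (0.35 log units; beyond the scatter) as the step, while the step to it from the furan-2-yl group, a 1.2-fold lower number from compound 2 to compound 4 (0.09 log units; within the scatter) on the printed values, stays within the scatter, so the furan-2-yl ring of compound 2 no longer stands apart. Nothing available gives a reason for the step from trifluoromethyl to nitro.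

With only these two substituents on the ring, no trend can be drawn at this position. As far as these compounds go, whether an amine, a carboxylic acid or a methoxy group there would sit with compound 3 or with compound 4 remains open.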